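A few compounds are considered here, and "the series" means these few. Any claim that something is new, unique, unknown or untested is made for them only; others in the source may bear on it.

Working notes on the series. In a functional assay on HepG2 cells (Homo sapiens) for antiproliferative activity, read by spectrophotometry, with a stated time of 2 days (a lower number here means a stronger inhibitor of growth, a higher number a weaker inhibitor of growth), compound 1 `COc1ccc(Nc2ncc(C(F)(F)F)c(N3Cc4cccc(N(C)S(C)(=O)=O)c4C3)n2)cc1C(F)(F)F` gives only a limit, > 30000 nM. Compound 2 `CN(c1cccc2c1CN(c1nc(Nc3ccc(C(F)(F)F)cc3)ncc1C(F)(F)F)C2)S(C)(=O)=O` likewise returns a limit, > 30000 nM. Compound 3 `CN(c1cccc2c1CN(c1nc(Nc3ccc(Cl)c(C(F)(F)F)c3)ncc1C(F)(F)F)C2)S(C)(=O)=O` gives 16000 nM. The steps of an at least 1.8-fold lower number from compound 1 to compound 3 (0.27 log units; that floor lies within the scatter) and an at least 1.8-fold lower number from compound 2 to compound 3 (0.27 log units; that floor lies within the scatter) reach only floors that sit within the scatter, and the step that the two limits leave unreadable from compound 1 to compound 2 cannot be read because of the limit of > 30000 nM in this assay, at which 2 of the 3 values shown sit. Compound 4 `COc1cc(Nc2ncc(C(F)(F)F)c(N3Cc4cccc(N(C)S(C)(=O)=O)c4C3)n2)cc(OC)c1` carries 3,5-dimethoxyphenyl in place of 4-methoxy-3-(trifluoromethyl)phenyl on a nitrogen on an aromatic ring. Among the compounds with values here, no measured step probes that change, and compound 1 itself stands at a limit, so nothing beyond the scatter is expected. The estimated step is a number no higher from compound 1 to compound 4 (the limit leaves the size open). Compound 4 is expected to give about 30000 nM in this assay, within 10000 nM to 90000 nM, most likely again as a limit.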

Compound 4, concentration for 50% growth inhibition: 1800 nM
The estimate for compound 4 lay 17-fold (1.22 log units) above the measured number; measured number below the stated range.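

In this assay, within the data shown here, the group on the nitrogen on an aromatic ring can move the number beyond the scatter, which the earlier compounds did not show: 3,5-dimethoxyphenyl gives an 8.9-fold lower number from compound 3 to compound 4 (0.95 log units; beyond the scatter) against 4-chloro-3-(trifluoromethyl)phenyl, the one step here between two actual numbers. The steps of an at least 16-fold lower number from compound 1 to compound 4 (1.22 log units; beyond the scatter) and an at least 16-fold lower number from compound 2 to compound 4 (1.22 log units; beyond the scatter) also lie beyond the scatter, but they are floors with their true size left open: the limit of > 30000 nM in this assay, at which 2 of the 4 values shown sit.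

The compounds shown do not separate the gain from the methoxy groups of compound 4 from the loss of trifluoromethyl. Going by these compounds, how an amine or a carboxylic acid would read in place of a methoxy group remains open.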